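Adding a second chloro to a purine-like core

This account rests on a few compounds, and the source may have more. Where it says the series, first, only, none or still open, it means among the compounds named here.

Measured so far:
- compound 1, `ClCc1cccc(Cn2cnc3c(Cl)ncnc32)c1`: 3380 nM
- compound 2, `ClCc1cccc(Cn2cnc3c(Cl)nc(Cl)nc32)c1`: 3460 nM
- compound 3, `ClCc1ccccc1Cn1cnc2ncnc(Cl)c21`: 5120 nM

All three compounds were tested in a functional assay on UACC-62 cells (Homo sapiens) for cytotoxicity, read by sulforhodamine B assay, with a stated time of 48 h; on this read-out lower numbers stand for stronger inhibition of growth and higher numbers for weaker inhibition of growth. Compound 3 has the highest of the three numbers, but its gap to compound 2 and its gap to compound 1 both fall within the scatter of repeated measurements, so the three cannot be told apart on these data.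

Compound 4, `ClCc1ccccc1Cn1cnc2nc(Cl)nc(Cl)c21`, has not yet been measured. It differs from compound 3 in one place: chloro in place of hydrogen on an aromatic carbon.

The same kind of change has been seen once before, in the step from compound 1 to compound 2, which gave a 1.0-fold higher number from compound 1 to compound 2 (0.01 log units; within the scatter). On that single precedent, the added chloro made no difference that rises above the scatter. The step from compound 3 to compound 4 is therefore expected to be of the same kind: a change in this assay of no meaningful size in either direction, estimated as a 1.0-fold lower number from compound 3 to compound 4 (0.01 log units; within the scatter).

Compound 4 is thus expected to give about 5000 nM, with a likely range from 2500 nM to 10000 nM.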

Compound 4, concentration for total growth inhibition: 2810 nM
For compound 4 the middle estimate is 1.8-fold (0.25 log units) above the measured one; the measured number falls inside the stated range.
By their numbers in this assay, from the lowest: compounds 4, 1, 2 and 3 (each within the scatter of the next).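

Chloro in place of hydrogen on this aromatic carbon, between two ring nitrogen atoms, has now been seen on a second core, and in this assay it gives a 1.8-fold lower number from compound 3 to compound 4 (0.26 log units; within the scatter). The change has therefore shown no step beyond the scatter on either core, and the two steps cannot be told apart from each other: the same change on two cores in this assay, a 1.0-fold higher number (0.01 log units; within the scatter) from compound 1 to compound 2 and a 1.8-fold lower number (0.26 log units; within the scatter) from compound 3 to compound 4, 1.9-fold (0.27 log units) apart, within the scatter of two such steps. On both cores, this position carries the chloro with no loss of growth inhibition that rises above the scatter.

Hydrogen and chloro are the only groups seen at this position, leaving open whether it responds to any change at all. An amine, a methoxy group or a longer chain in its place might give a step beyond the scatter, and the compounds shown cannot indicate its direction.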